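The compounds below may be only part of what the source reports. "The series", "measured", "known", "first", "only" and "open" are said of these compounds alone.

Measured compounds:
compound 1, `COc1ncc(-c2ccc3nc(NC(=O)NCCN4CCCC4)sc3c2)cc1NS(=O)(=O)c1ccc(F)cc1`, in a functional assay on MCF7 cells (Homo sapiens) for antiproliferative activity, read by MTT assay, with a stated time of 72 h (on this read-out lower numbers stand for stronger inhibition and higher numbers for weaker inhibition), compound 1 gives 410 nM
compound 2, `COc1ncc(-c2ccc3nc(NC(=O)NCCN4CCCCC4)sc3c2)cc1NS(=O)(=O)c1ccc(F)cc1`, in this assay compound 2 gives 450 nM

Among the compounds with values here, compound 2 holds the highest of the two numbers so far, with compound 1 nearest, and the step between them, a 1.1-fold higher number from compound 1 to compound 2 (0.04 log units; within the scatter), stays within the scatter, so the two compounds cannot be told apart on this read-out. That step is the only one recorded and it is also the one that bears on the next change, since both alter the group on a saturated chain carbon, two bonds along the chain from an amide-type nitrogen.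

Compound 3, `COc1ncc(-c2ccc3nc(NC(=O)NCCN4CCN(C)CC4)sc3c2)cc1NS(=O)(=O)c1ccc(F)cc1`, is not yet measured. It differs from compound 2 in one place: 4-methylpiperazin-1-yl in place of piperidin-1-yl on a saturated chain carbon, two bonds along the chain from an amide-type nitrogen. Within the data shown here, the one comparable step, piperidin-1-yl in place of pyrrolidin-1-yl at the same place, moved the number only within the scatter, so no step beyond the scatter is expected in this assay for this exchange either; the second hetero atom entering the ring is an untested element, which widens the range. Compound 3 is estimated at 500 nM, between 200 nM and 1300 nM, which would mean an expected step of a 1.1-fold higher number from compound 2 to compound 3 (0.05 log units; within the scatter).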

Compound 3, half-maximal inhibitory concentration: 470 nM
For compound 3 the middle estimate is 1.1-fold (0.03 log units) above the measured one, and the stated range covers the measured number.
By their numbers in this assay, from the lowest: compounds 1, 2 and 3 (each within the scatter of the next).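

In this assay, 4-methylpiperazin-1-yl in place of piperidin-1-yl on a saturated chain carbon, two bonds along the chain from an amide-type nitrogen, gives a 1.0-fold higher number from compound 2 to compound 3 (0.02 log units; within the scatter), and the same group in place of pyrrolidin-1-yl gives a 1.1-fold higher number from compound 1 to compound 3 (0.06 log units; within the scatter). The earlier pair covered only rings with 1 hetero atom, whereas these steps extend the comparison to a six-membered non-aromatic ring with 2 hetero atoms and a group of 7 heavy atoms, and the read-out still does not separate the three compounds. No measurement at hand explains this insensitivity to the exchange.

Going by these compounds, whether a morpholin-4-yl ring, an open-chain dimethylamino group, a carboxylic acid or a longer chain at this place would give a step beyond the scatter remains open. The compounds shown also share the rest of the structure, including the 4-fluorophenyl sulfonamide and the urea, so they leave open how far the number depends on those parts and whether this tolerance holds outside the shared core.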